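Hydroxyphenyl placement on the shared core of compound 2

This account rests on a few compounds, and the source may have more. Where it says the series, first, only, none or still open, it means among the compounds named here.

Measured so far:
compound 1, `Oc1ccc(-c2cc(-c3cccs3)cc(-c3cccc(O)c3)n2)cc1`, 1770 nM in a functional assay on HCT-15 cells (Homo sapiens) for cytotoxicity, read by CCK-8 assay; on this read-out higher numbers stand for weaker inhibition and lower numbers for stronger inhibition
compound 2, `Oc1cccc(-c2cc(-c3cccnc3)cc(-c3ccccc3O)n2)c1`, 8280 nM

Compound 2 gives the highest of the two numbers in this assay; its nearest neighbour is compound 1, whose number is lower by a margin that lies beyond the usual scatter. Within the data shown here, compound 1 and compound 2 differ in two places at once, so no single step can be read off between them; their values show only that the pair spans a clear gap.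

Compound 3, `Oc1ccc(-c2cc(-c3cccnc3)cc(-c3cccc(O)c3)n2)cc1`, not yet measured, differs from compound 2 in one place: 4-hydroxyphenyl in place of 2-hydroxyphenyl on an aromatic carbon. The same atoms are present, joined differently. Among the measured compounds shown here, since no measured pair isolates this change, the step from compound 2 to compound 3 in this assay cannot be taken from the data; a modest step towards a lower number is expected, one that may or may not pass the scatter, a 1.8-fold lower number from compound 2 to compound 3 (0.26 log units; within the scatter), because compound 1, which also carries 4-hydroxyphenyl, gives 1770 nM. The estimate for compound 3 in this assay is 4500 nM, with a range from 1500 nM to 13000 nM.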

Compound 3, half-maximal inhibitory concentration: > 50000 nM
Compound 3: no number, only a limit; the forecaster's own chance of this, stated with the estimate: 5%; at least 11-fold (1.04 log units) between middle value and limit.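

In this assay compound 3 gives > 50000 nM, which is a limit of the assay and not a number. At this place, next to the ring nitrogen, the exchange of two groups with the same atoms is not neutral, with 4-hydroxyphenyl in place of 2-hydroxyphenyl giving an at least 6.0-fold higher number from compound 2 to compound 3 (0.78 log units; beyond the scatter), and with the hydroxyphenyl groups held, pyridin-3-yl in place of thiophen-2-yl gives an at least 28-fold higher number from compound 1 to compound 3 (1.45 log units; beyond the scatter), so 4-hydroxyphenyl does not by itself go with the lower number and its effect here depends on the other group on the core. Both steps give only a minimum size, because the value of compound 3 rests on a limit: the limit of > 50000 nM in this assay, at which 1 of the 3 values shown sits.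

Open is whether 2-hydroxyphenyl would keep its lower number on a core that carries thiophen-2-yl in place of pyridin-3-yl, since the series shown holds no such pair. Also open, going by these compounds, is whether the hydroxy group itself matters at this place, a question that a 4-aminophenyl group, a 4-methoxyphenyl group or a carboxylic acid on the same phenyl ring could address.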